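This account rests on a few compounds, and the source may have more. Where it says the series, first, only, none or still open, it means among the compounds named here.

Compound 1 `O=C(Cc1ccccn1)NC1CCN(Cc2ccccc2)CC1` and compound 2 `O=C(Cc1cccnc1)NC1CCN(Cc2ccccc2)CC1` share one core and differ only in the pyridyl ring attached to the saturated chain carbon bound to the carbonyl carbon. In an assay on membranes from brain (Cavia porcellus) for binding affinity to Sigma non-opioid intracellular receptor 1 (Homo sapiens), read by radioligand binding (a lower number here means a stronger inhibitor, a higher number a weaker inhibitor), compound 1 gives 236 nM and compound 2 gives 269 nM. Putting pyridin-3-yl in place of pyridin-2-yl gives a 1.1-fold higher number from compound 1 to compound 2 (0.06 log units; within the scatter). For the measured compounds named here, on the numbers so far compound 2 and compound 1 cannot be told apart within the scatter; compound 2 is the direct reference for the next change. Compound 3 `O=C(Cc1ccncc1)NC1CCN(Cc2ccccc2)CC1` is not yet measured in this assay. It differs from compound 2 by pyridin-4-yl in place of pyridin-3-yl on a saturated chain carbon bound to a carbonyl carbon. Going by the values given here, the only step that bears on this is the one from compound 1 to compound 2, which stayed within the scatter, so a step of a 1.0-fold higher number from compound 2 to compound 3 (0.02 log units; within the scatter) is expected in this assay, with no change beyond the scatter. For compound 3 the estimate in this assay is 280 nM, in the range 150 nM to 520 nM.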

Compound 3, inhibition constant: 298 nM
The estimate for compound 3 lay 1.1-fold (0.03 log units) below the measured number, within the range that was stated.
By their numbers in this assay, from the lowest: compounds 1, 2 and 3 (each within the scatter of the next).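

In this assay, pyridin-4-yl in place of pyridin-3-yl gives a 1.1-fold higher number from compound 2 to compound 3 (0.04 log units; within the scatter), and pyridin-4-yl in place of pyridin-2-yl gives a 1.3-fold higher number from compound 1 to compound 3 (0.10 log units; within the scatter). With pyridin-4-yl included, all three pyridyl attachments on the saturated chain carbon bound to the carbonyl carbon have been read, and even the step spanning the two ends of the series stays within the scatter, so the attachment point of the pyridyl ring at this place does not separate these compounds in this assay. No supporting data are available to explain this lack of separation.

The three compounds vary only the pyridyl attachment, so they leave open how far this place tolerates a different group, such as an amine or a carboxylic acid in place of the pyridyl ring. Also open, on these data alone, is whether a longer chain carrying the pyridyl ring would move the number beyond the scatter.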